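The source may report more compounds than this note shows. Statements on the series, on what has been measured and on what is new or still open speak of the compounds shown alone.

Measured compounds, in an assay on membranes from Sf9 cells for displacement of a labelled ligand from histamine H2 receptor (Homo sapiens), read by scintillation counting, with a stated time of 60 min; a lower number here means a stronger inhibitor, a higher number a weaker inhibitor:
compound 1, `Cc1nc(N)sc1CCCN/C(N)=N/C(=O)NCc1ccco1`, gives 10.5 nM
compound 2, `Cc1nc(N)sc1CCCN/C(N)=N/C(=O)NC(C)c1ccc(F)cc1`, gives 31.6 nM

Of the two measured compounds, compound 1 stands with the lower number in this assay, and compound 2 with the higher one; the gap between them lies beyond the usual scatter, so compound 1 is the stronger of the two. The two share the same core and differ only in the group attached to the amide-type nitrogen.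

Compound 3, `CCCCCNC(=O)/N=C(\N)NCCCc1sc(N)nc1C`, is not yet measured. It departs from compound 1 by butyl in place of furan-2-yl on a saturated chain carbon bound to an amide-type nitrogen. Among the compounds with values here, no pair of measured compounds shows this same change, so the expected step cannot be read from a measured step. What the numbers do show is that replacing the group on that nitrogen, as between compound 1 and compound 2, moved the number upward by more than the scatter. An open chain in place of the five-membered aromatic ring is therefore expected to weaken binding somewhat, by a step that is expected to be a 2.4-fold higher number from compound 1 to compound 3 (0.38 log units; beyond the scatter), modest but beyond the scatter. Compound 3 is expected to give 25 nM, in the range from 8 nM to 80 nM.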

Compound 3, inhibition constant: 4.47 nM
Compound 3: middle estimate off by 5.6-fold (0.75 log units), on the high side, outside the stated range (below it).
By their numbers in this assay, from the lowest: compound 3; then compound 1; then compound 2.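

Butyl in place of furan-2-yl on a saturated chain carbon bound to an amide-type nitrogen gives, in this assay, a 2.3-fold lower number from compound 1 to compound 3 (0.37 log units; beyond the scatter) and so makes compound 3 the stronger inhibitor of this pair. The five-membered aromatic ring of compound 1 is therefore not required at this position for a low number: the pentyl group of compound 3, with no ring and no hydrogen-bond acceptor, does better, although this rests on a single pair. No measurement shown here bears on why the number falls with this change.

As far as these compounds go, it remains open how the number depends on the length and shape of the chain, for instance whether a propyl, a heptyl or a branched isopentyl group would take it lower or raise it again, and whether a saturated cyclohexyl ring would match the open chain. Also open, from the compounds shown here alone, is whether a hydroxyl group or an amine at the far end of the pentyl chain would keep the number of compound 3 or lose it.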